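A few compounds are considered here, and "the series" means these few. Any claim that something is new, unique, unknown or untested is made for them only; others in the source may bear on it.

Of the compounds shown here, two have so far been tested in a functional assay on the whole organism for inhibition, with Rattus norvegicus as the target; on this read-out lower numbers stand for an effect already at smaller amounts and higher numbers for an effect only at larger amounts of compound. Compound 1 `CC1CCn2c(ncc(C(=O)O)c2=O)/C1=N/Nc1ccccc1` carries a plain phenyl on the amine nitrogen of the hydrazone; in this assay compound 1 gives 32 umol/kg. Compound 2 `CC1CC/C(=N\Nc2ccccc2F)c2ncc(C(=O)O)c(=O)n21` carries a 2-fluorophenyl at that nitrogen and also differs from compound 1 elsewhere, so the two cannot be read as a single change; in this assay compound 2 gives 5 umol/kg. Of the two numbers, compound 2 holds the lower one, and compound 1 sits well above it, beyond the scatter, so compound 2 is the more potent of the pair. The next compound, compound 3 `CC1CC/C(=N\Nc2ccc(F)cc2)c2ncc(C(=O)O)c(=O)n21`, keeps everything of compound 2 apart from one change: 4-fluorophenyl in place of 2-fluorophenyl on an amine nitrogen. Among the compounds with values here, nothing measured so far separates a 2-fluorophenyl from a 4-fluorophenyl at this place, so the size of the step is uncertain. The expectation is a small step, a 1.6-fold higher number from compound 2 to compound 3 (0.20 log units; within the scatter), not clearly beyond the scatter and if anything toward a higher number. Compound 3 is therefore expected to give about 8 umol/kg in this assay, within a range from 3 umol/kg to 25 umol/kg.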

Compound 3, dose for 50% inhibition: 12.2 umol/kg
Compound 3: middle estimate off by 1.5-fold (0.18 log units), on the low side; the measured number falls inside the stated range.
By their numbers in this assay, from the lowest: compound 2; then compound 3; then compound 1.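

In this assay, within the data shown here, putting 4-fluorophenyl in place of 2-fluorophenyl on the amine nitrogen gives a 2.4-fold higher number from compound 2 to compound 3 (0.39 log units; beyond the scatter), the first change in this set that can be read on its own. The two groups are made of the same atoms and differ only in where the fluorine sits on the phenyl ring, so this modest step, beyond the scatter, shows that the location of the fluorine matters at this position, with the 2-fluorophenyl group giving the lower number. The data offer no measurement that would explain why these two groups differ.

The compounds shown leave open how much the fluorine contributes at all, since compound 1 carries a plain phenyl but also differs from compound 2 elsewhere, so no direct comparison with a fluorine-free ring on the same core is available. They also leave open whether the lower number for compound 2 is specific to fluorine or would carry over to other groups on the amine nitrogen, such as 3-fluorophenyl, 2-chlorophenyl or 2-methoxyphenyl.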